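The source may report more compounds than this note shows. Statements on the series, on what has been measured and on what is new or still open speak of the compounds shown alone.

Working notes on the series in a functional assay on A549 cells (Homo sapiens) for inhibition, read by sulforhodamine B assay, with a stated time of 74 h; on this read-out higher numbers stand for weaker inhibition and lower numbers for stronger inhibition. Compound 1 `O=C1C=CC2(C=C1)OCC(=O)N2S(=O)(=O)c1ccc([N+](=O)[O-])cc1` gives > 10000 nM as a limit of the assay and not a number. Compound 2 `N#Cc1cccc(S(=O)(=O)N2C(=O)COC23C=CC(=O)C=C3)c1` gives 1910 nM and compound 3 `O=C1C=CC2(C=C1)OCC(=O)N2S(=O)(=O)c1ccc(F)c(F)c1` gives 50 nM on the shared core. Going by the values given here, no measured pair differs in one place only, so no direct step is available. Compound 4 `O=C1C=CC2(C=C1)OCC(=O)N2S(=O)(=O)c1ccc(C(F)(F)F)cc1` carries trifluoromethyl in place of the nitro of compound 1 on an aromatic carbon, para to a large group: trifluoromethyl in place of nitro on an aromatic carbon in all. In this assay a move toward stronger inhibition is expected, resting on compound 2 at 1910 nM and compound 3 at 50 nM with wide uncertainty. The estimated step of an at least 20-fold lower number from compound 1 to compound 4 (1.30 log units; beyond the scatter) is only an expectation. For compound 4 the estimated value is 500 nM with an expected range from 60 nM to 5000 nM in this series.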

Compound 4, half-maximal inhibitory concentration: > 10000 nM
Compound 4 was reported as a limit; the forecaster's own chance of this, stated with the estimate: 15%; middle value at least 20-fold (1.30 log units) away from the limit.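

Going by these compounds alone, compound 1 and compound 4 are both reported as limits and not numbers, so no step between them can be read: the limit of > 10000 nM in this assay, at which 2 of the 4 values shown sit. The compounds shown leave open whether trifluoromethyl and nitro on an aromatic carbon differ at all in inhibition on the shared core.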